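Moving the Methoxy Group: Compound 3 to Compound 4

A few compounds are considered here, and "the series" means these few. Any claim that something is new, unique, unknown or untested is made for them only; others in the source may bear on it.

Compound 3 `COc1ccc(-c2c(S(=O)(=O)c3cc(F)cc(F)c3)cnc3cc(F)ccc23)cc1` was run in an ADME assay on microsomes from liver (Homo sapiens) for metabolic stability, tested at 2.5 uM (on this read-out higher numbers stand for fast clearance and lower numbers for slow clearance), where compound 3 gives 1.51 mL/min, the second highest of the three numbers seen. Its nearest neighbour is compound 1 `COc1ccc(-c2c(S(=O)(=O)c3ccc(F)c(F)c3)cnc3cc(F)ccc23)cc1`, which in this assay gives 1.1 mL/min; that step, a 1.4-fold higher number from compound 1 to compound 3 (0.14 log units; within the scatter), is within the scatter. Compound 2 `COc1cccc(-c2c(S(=O)(=O)c3cc(Cl)cc(Cl)c3)cnc3c(F)cccc23)c1` gives 2.31 mL/min in this assay, again within the scatter of compound 3. Compound 4 `COc1cccc(-c2c(S(=O)(=O)c3cc(F)cc(F)c3)cnc3cc(F)ccc23)c1` differs from compound 3 in one place: 3-methoxyphenyl in place of 4-methoxyphenyl on an aromatic carbon. For the measured compounds named here, no measured step changes this group on its own; compound 2 carries the same 3-methoxyphenyl but differs from compound 3 elsewhere as well. Going by the values given here, with the one measured step within the scatter, the step expected here is a 1.0-fold lower number from compound 3 to compound 4 (0.00 log units; within the scatter), none beyond the scatter. For compound 4 the estimate is 1.5 mL/min, with a range from 0.8 mL/min to 2.8 mL/min.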

Compound 4, intrinsic clearance in a liver preparation (reported as CLH), per the amount of preparation that the assay uses: 1.81 mL/min
For compound 4 the middle estimate is 1.2-fold (0.08 log units) below the measured one; low and high end bracket the measured number.
By their numbers in this assay, from the lowest: compounds 1, 3, 4 and 2 (each within the scatter of the next, the first and the last beyond it).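

In this assay, this position now has a direct reading of its own. Putting 3-methoxyphenyl in place of 4-methoxyphenyl on an aromatic carbon gives a 1.2-fold higher number from compound 3 to compound 4 (0.08 log units; within the scatter) and so leaves the read-out within the scatter, which means that with the rest of the structure held constant the two methoxyphenyl isomers cannot be told apart. Nothing available explains this result. Going by these compounds, it remains open whether an amine or a carboxylic acid in place of the methoxy group would shift clearance beyond the scatter, and whether the same isomer swap would behave alike with other sulfonyl groups.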